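The source may hold more compounds than are shown below. What is called first, only, known or untested is meant among the compounds shown, and "the series" means these compounds.

Of the compounds shown here, three have been measured in an assay on HEK293 cells for agonist activity at vitamin D3 receptor (Homo sapiens), read by a beta-galactosidase reporter; on this read-out lower numbers stand for an effect already at smaller amounts and higher numbers for an effect only at larger amounts of compound. Compound 1 `CCC(CC)(c1ccc(OC[C@@H](O)CO)c(C)c1)c1ccc(OC[C@H](O)C(C)(C)OCCCCCCCCO)c(C)c1` gives 1200 nM. Compound 2 `CCCCCCOC(C)(C)[C@H](O)COc1ccc(C(CC)(CC)c2ccc(OC[C@@H](O)CO)c(C)c2)cc1C` reaches only the limit of the assay, > 10000 nM, so no single number is known for it. For compound 3 `CCCCCCCCOC(C)(C)[C@@H](O)COc1ccc(C(CC)(CC)c2ccc(OC[C@@H](O)CO)c(C)c2)cc1C` the result is recorded as "not active" (no number reported), again without a number. Compound 2 therefore stands at the limit of > 10000 nM in this assay, at which 1 of the 3 values shown sits, and it shares with compound 3 the absence of a measured number, while compound 1 alone has a value on the scale.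

The next compound, compound 4 `CCCCCCCCCCOC(C)(C)[C@H](O)COc1ccc(C(CC)(CC)c2ccc(OC[C@@H](O)CO)c(C)c2)cc1C`, differs from compound 2 in one place: butyl in place of hydrogen on a saturated chain carbon, six bonds along the chain from an oxygen on a saturated carbon. Among the compounds with values here, no step between measured compounds is available to show what such a change does in this assay. On the evidence of compound 2 alone, whose result in this assay is the limit > 10000 nM, compound 4 is expected to fall at or beyond that limit as well, so the expected step from compound 2 to compound 4 is a step that the limit leaves unreadable from compound 2 to compound 4, which is not a change that can be told from the scatter. The estimate for compound 4 is 20000 nM, within a range from 8000 nM to 60000 nM.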

Compound 4, half-maximal effective concentration: "not active" (no number reported)
Compound 4: no number reported; the estimate stays without a comparison.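

Within the data shown here, compound 4 is recorded as not active, without a number, so no step from compound 2 to compound 4 can be read. For compound 2 the entry > 10000 nM is only a limit of the assay. In this assay the compounds shown leave open whether butyl in place of hydrogen changes the effect at all.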